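Amino-chloro aryl amide expected to stay weakly cytotoxic

A few compounds are considered here, and "the series" means these few. Any claim that something is new, unique, unknown or untested is made for them only; others in the source may bear on it.

Compound 2 `O=C(Nc1ccc(S(=O)(=O)N2CCCC2)cc1)c1ccc(F)cc1` carries a 4-fluorophenyl on the carbonyl carbon of the shared core. In an ADME assay on Vero cells (Chlorocebus sabaeus) for cytotoxicity, read by MTT assay (on this read-out lower numbers stand for higher toxicity in this test and higher numbers for lower toxicity in this test), compound 2 gives > 300000 nM, which is a limit of the assay and not a number. Compound 1 `O=C(Nc1ccc(S(=O)(=O)N2CCCC2)cc1)c1ccc(C(F)(F)F)cc1` is its trifluoromethyl counterpart. In this assay compound 1 likewise reaches only a limit, > 300000 nM. The step that the two limits leave unreadable from compound 1 to compound 2 cannot be sized because both values sit at the limit of > 300000 nM in this assay, at which 2 of the 3 values shown sit. For the measured compounds named here, compound 3 `O=C(Nc1ccc(S(=O)(=O)N2CCCC2)cc1)c1cc(C(F)(F)F)ccc1F`, which carries both a trifluoromethyl and a fluorine on the benzoyl ring, is the only member of the set with a number in this assay, 76000 nM, but no single step connects it to compound 2.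

Compound 4 `Nc1ccc(C(=O)Nc2ccc(S(=O)(=O)N3CCCC3)cc2)c(Cl)c1` differs from compound 2 by 4-amino-2-chlorophenyl in place of 4-fluorophenyl on a carbonyl carbon. Going by the values given here, no measured step bears on this change: the one step that exists, from compound 1 to compound 2, is unreadable. Among the compounds with values here, the set shows only that a numbered value below the limit does occur, as compound 3 demonstrates. Compound 4 is therefore expected to move from compound 2 by about an at least 1.5-fold lower number from compound 2 to compound 4 (0.17 log units; that floor lies within the scatter), a step not expected to exceed the scatter. Compound 4 is estimated at 200000 nM, with a range from 60000 nM to 600000 nM.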

Compound 4, half-maximal cytotoxic concentration: > 300000 nM
Compound 4: a limit, no number; the forecaster's own chance of this, stated with the estimate: 45%; at least 1.5-fold (0.17 log units) between middle value and limit.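

No new step can be read from compound 2 to compound 4: in this assay each of the two compounds gives a limit of the assay and not a number, so the change between them has no readable size: the limit of > 300000 nM in this assay, at which 3 of the 4 values shown sit.

The compounds shown leave open whether 4-amino-2-chlorophenyl in place of 4-fluorophenyl on a carbonyl carbon changes the read-out at all.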